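The compounds below may be only part of what the source reports. "The series", "measured", "known", "first", "only" and "open" are said of these compounds alone.

Compound 2 `Cc1cc(Nc2cc(Cl)cc(S(F)(F)(F)(F)F)c2)nc(N)n1` was tested in an assay on cells for inhibition of S-adenosylmethionine decarboxylase proenzyme (Homo sapiens), read by mass spectrometry, at pH 7.2; a higher number here means a weaker inhibitor, a lower number a stronger inhibitor. There compound 2 gives > 180000 nM, which is a limit of the assay and not a number. Compound 3 `Cc1cc(Nc2cc(Br)cc(S(F)(F)(F)(F)F)c2)nc(N)n1` likewise gives a limit, > 180000 nM. Compound 1 `Nc1cccc(Nc2cc(Cl)cc(Cl)c2)n1` also sits at a limit, > 180000 nM. The step from compound 2 to compound 3, a step that the two limits leave unreadable from compound 2 to compound 3, is bromo in place of chloro on an aromatic carbon, and its size is not readable; all three values rest at the limit of > 180000 nM in this assay, at which 3 of the 3 values shown sit. Compound 4 `Cc1cc(Nc2cc(Cl)cc(-c3ccc(O)cc3)c2)nc(N)n1` carries a group of 7 heavy atoms (6 carbon, 1 oxygen; one six-membered aromatic ring of carbon only) in place of a group of 6 heavy atoms (5 fluorine, 1 sulfur; no ring), on an aromatic carbon. Among the measured compounds shown here, no measured step bears on this change; the only one available is unreadable. Compound 4 is therefore expected to remain near the limit, with an estimate of 180000 nM and a range from 20000 nM to 500000 nM. That means an expected step of a number no higher from compound 2 to compound 4 (the limit leaves the size open).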

Compound 4, half-maximal inhibitory concentration: > 180000 nM
Compound 4: only a limit was reported; the forecaster's own chance of this, stated with the estimate: 75%; the middle value lies on the limit itself.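

Among the compounds shown here, compound 2 and compound 4 both give only a limit in this assay, so no step between them can be read: the limit of > 180000 nM in this assay, at which 4 of the 4 values shown sit. The compounds shown leave open which change to the structure, if any, would give a readable number.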